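Methoxy to hydrogen on compound 2

The source may report more compounds than this note shows. Statements on the series, on what has been measured and on what is new or still open speak of the compounds shown alone.

In a functional assay, read by spectrophotometry, with a stated time of 10 min (a lower number here means that less compound is needed, a higher number that more compound is needed for the effect), compound 2 (`COC(=O)C1=C(C)NC(=O)NC1c1ccc(OC)cc1`) gives 1.92 ug/mL in this series. Compound 3 (`COC(=O)C1=C(C)NC(=O)NC1c1ccc([N+](=O)[O-])cc1`) gives 1.71 ug/mL and compound 1 (`CCOC(=O)C1=C(C)NC(=O)NC1c1cccc([N+](=O)[O-])c1`) gives 1.16 ug/mL on the same read-out. All three values lie within the scatter of one another, so compound 2 sits in a flat set with no real order among its members.

Compound 4 (`COC(=O)C1=C(C)NC(=O)NC1c1ccccc1`) is still unmeasured and follows from compound 2 by one change (hydrogen in place of methoxy on an aromatic carbon): hydrogen in place of methoxy on an aromatic carbon, para to a large group. Going by the values given here, only one measured step touches that methoxy, and it is small (a 1.1-fold lower number from compound 2 to compound 3 (0.05 log units; within the scatter)): nitro in place of methoxy on an aromatic carbon. Among the compounds with values here, compound 1 differs from compound 2 in more than one place and offers no clean step. Within the data shown here, no measured compound carries hydrogen there, so the evidence is indirect.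

No shift beyond the scatter is therefore expected in this assay from this change, and no firm direction can be argued. The estimate amounts to a small expected step (a 1.1-fold lower number from compound 2 to compound 4 (0.03 log units; within the scatter)). For compound 4 the estimated value is 1.8 ug/mL with 1 ug/mL to 3.2 ug/mL as the expected range.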

Compound 4, half-maximal effective concentration: 2.23 ug/mL
For compound 4 the middle estimate is 1.2-fold (0.09 log units) below the measured one; the range from low to high includes it.
By their numbers in this assay, from the lowest: compounds 1, 3, 2 and 4 (each within the scatter of the next).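

With hydrogen now on this aromatic carbon, para to a large group, the position has a reference compound carrying neither methoxy nor nitro. In this assay, hydrogen in place of methoxy gives a small step (a 1.2-fold higher number from compound 2 to compound 4 (0.07 log units; within the scatter)), and hydrogen in place of nitro gives a similarly sized one (a 1.3-fold higher number from compound 3 to compound 4 (0.12 log units; within the scatter)). Both steps lie within the scatter, so methoxy, nitro and hydrogen cannot be told apart at this position in compounds 2, 3 and 4, and neither group shows a measurable gain or loss against plain hydrogen. No measurement here bears on why these three compounds read alike.

The compounds shown leave open whether this flat reading extends to groups of another kind at the same position, such as an amine, a carboxylic acid or a longer alkoxy chain like butoxy. Going by these compounds alone, the role of the ester on the shared core also remains open, since compound 1 differs from the others in more than one place and gives no clean step.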